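Removal of a ring hydroxy in two aryl-amino coumarin analogues

The compounds below may be only part of what the source reports. "The series", "measured", "known", "first", "only" and "open" are said of these compounds alone.

Measured compounds:
compound 1 `COc1ccc(-c2c(Nc3cc(OC)c(OC)c(OC)c3)c3ccccc3oc2=O)cc1`, 77300 nM
compound 2 `COc1ccc(-c2c(Nc3cc(OC)c(OC)c(OC)c3)c3ccc(O)cc3oc2=O)cc1`, 49700 nM
compound 3 `COc1ccc(-c2c(Nc3ccc(C)c(O)c3)c3ccc(O)cc3oc2=O)cc1`, a limit only, > 75300 nM

In a functional assay on HepG2 cells (Homo sapiens) for antiproliferative activity, read by MTT assay, with a stated time of 48 h (a higher number here means a weaker inhibitor, a lower number a stronger inhibitor), compound 2 gives 49700 nM and compound 1 gives 77300 nM. The change from compound 2 to compound 1 is hydrogen in place of hydroxy on an aromatic carbon, and it made a step of a 1.6-fold higher number from compound 2 to compound 1 (0.19 log units; within the scatter). For compound 3 the value of > 75300 nM is a limit of the assay, not a number, as noted in the limit of > 75300 nM in this assay, at which 1 of the 3 values shown sits. The difference between the core of compound 2 and that of compound 3 is not broken down here.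

Compound 4 `COc1ccc(-c2c(Nc3ccc(C)cc3)c3ccc(O)cc3oc2=O)cc1` is not yet measured. From compound 3 to compound 4 the change is hydrogen in place of hydroxy on an aromatic carbon. This is the same kind of change as from compound 2 to compound 1, but the place differs: there the hydroxy sat on a ring that is part of a fused system, meta and para to a fused ring, here it sits ortho to a methyl group and meta to a large group. Since the earlier step of a 1.6-fold higher number from compound 2 to compound 1 (0.19 log units; within the scatter) stayed within the scatter, and compound 3 already stands at the limit > 75300 nM, compound 4 is expected to sit at or beyond that limit, a step that the limit leaves unreadable from compound 3 to compound 4. The estimate for compound 4 in this assay is 110000 nM, between 50000 nM and 300000 nM.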

Compound 4, half-maximal inhibitory concentration: 88300 nM
Estimate against measurement, compound 4: 1.2-fold (0.10 log units) above; the measured number falls inside the stated range.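

No size can be read for the step between compound 3 and compound 4, since compound 3 stands only at a limit of the assay: the limit of > 75300 nM in this assay, at which 1 of the 4 values shown sits.

The compounds shown leave open whether replacing 3-hydroxy-4-methylphenyl with 4-methylphenyl changes the number in this assay at all.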